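Shortening a Propoxy Chain to Methoxy

The source may report more compounds than this note shows. Statements on the series, on what has been measured and on what is new or still open speak of the compounds shown alone.

- Compound 1 `CC(C)CC(=O)Oc1ccc2oc(/C=C/[S+](C)[O-])cc(=O)c2c1`: 2300 nM
- Compound 2 `CCCOc1ccc2oc(/C=C/[S+](C)[O-])cc(=O)c2c1`: 1100 nM
- Compound 3 `COc1ccc2oc(/C=C/[S+](C)[O-])cc(=O)c2c1`: not yet measured

In a functional assay on A549 cells (Homo sapiens) for cytotoxicity, with a stated time of 48 h (on this read-out lower numbers stand for stronger inhibition and higher numbers for weaker inhibition), compound 2 gives the lower of the two numbers, 1100 nM. Compound 3 differs from it by hydrogen in place of ethyl on a saturated chain carbon bound to an oxygen on an aromatic ring: hydrogen in place of ethyl, which turns propoxy into methoxy. Among the measured compounds shown here, only one measured step bears on this, and only loosely, as it swaps a different group on an oxygen on an aromatic ring: a 2.1-fold lower number from compound 1 to compound 2 (0.32 log units; beyond the scatter). That step is modest, so a similarly small change is expected, probably towards a higher number. The expected step is a 1.4-fold higher number from compound 2 to compound 3 (0.13 log units; within the scatter). For compound 3 the estimated value is 1500 nM, ranging from 600 nM to 3800 nM.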

Compound 3, half-maximal inhibitory concentration: 1600 nM
Estimate against measurement, compound 3: 1.1-fold (0.03 log units) below; the measured number falls inside the stated range.
By their numbers in this assay, from the lowest: compounds 2, 3 and 1 (each within the scatter of the next, the first and the last beyond it).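

Removing the ethyl leaves a change that cannot be told from assay noise: a 1.5-fold higher number from compound 2 to compound 3 (0.16 log units; within the scatter) shows that propoxy and methoxy are not separated at this position. Methoxy is also not separated from the ester group of compound 1, with a 1.4-fold lower number from compound 1 to compound 3 (0.16 log units; within the scatter), so compound 3 sits within the scatter of both neighbours even though those two lie beyond it from each other. No supporting measurement accounts for this result. Going by these compounds, whether a longer chain such as hexyloxy, or a hydroxyl in place of methoxy, would give a clearly different number remains open.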